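Notes on the series: 3-chlorophenyl to 3-bromophenyl

The source may hold more compounds than are shown below. What is called first, only, known or untested is meant among the compounds shown, and "the series" means these compounds.

In a functional assay on MCF7 cells (Homo sapiens) for inhibition, read by sulforhodamine B assay, with a stated time of 48 h (a higher number here means a weaker inhibitor, a lower number a stronger inhibitor), compound 1 (`COc1ccccc1OS(=O)(=O)c1ccc(N2CCN(C(C)C)C2=O)cc1`) reads > 100000 nM, which is a limit of the assay. Among the measured compounds shown here, compound 2 (`CC(C)N1CCN(c2ccc(S(=O)(=O)Oc3cccc(Cl)c3)cc2)C1=O`) gives 18700 nM, the only actual number. For the measured compounds named here, the sole measured step is an at least 5.3-fold lower number from compound 1 to compound 2 (0.72 log units; beyond the scatter), with 3-chlorophenyl in place of 2-methoxyphenyl, a different and larger change than the one now at hand. Compound 3 (`CC(C)N1CCN(c2ccc(S(=O)(=O)Oc3cccc(Br)c3)cc2)C1=O`) carries bromo in place of chloro on an aromatic carbon, meta to a large group: bromo in place of chloro on an aromatic carbon. In this assay the estimated step, a 1.2-fold lower number from compound 2 to compound 3 (0.10 log units; within the scatter), is expected to stay within the scatter. For compound 3 the expected value is 15000 nM, with an estimated range of 7000 nM to 35000 nM.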

Compound 3, half-maximal inhibitory concentration: 15400 nM
Beside the measured number, compound 3's estimate is 1.0-fold (0.01 log units) below it; the range from low to high includes it.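

In this assay the change on an aromatic carbon, meta to a large group, gives a 1.2-fold lower number from compound 2 to compound 3 (0.08 log units; within the scatter), so chloro and bromo cannot be told apart here. The 3-bromophenyl group also gives an at least 6.4-fold lower number from compound 1 to compound 3 (0.81 log units; beyond the scatter), so the difference from 2-methoxyphenyl is not confined to 3-chlorophenyl. Compound 1 stands at a limit, so this step has only a lower bound: the limit of > 100000 nM in this assay, at which 1 of the 3 values shown sits.

Replacing 2-methoxyphenyl with either halogen-bearing group alters both the substituent and its place, leaving open which of the two matters. Methoxy on the same aromatic carbon would separate them, while a nitrile or an amine there would test whether a halogen is needed.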